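From compound 2 to compound 3: a side chain removed

A few compounds are considered here, and "the series" means these few. Any claim that something is new, unique, unknown or untested is made for them only; others in the source may bear on it.

Measured in a functional assay on MDA-MB-231 cells (Homo sapiens) for inhibition, read by MTT assay, with a stated time of 24 h; a higher number here means a weaker inhibitor, a lower number a stronger inhibitor:
- Compound 1 `CCOC1c2cc(OCc3cc(C)cc(C)c3)c(OCc3cc(C)cc(C)c3)cc2CCN1C(=O)OC(C)(C)C`: > 20000 nM, a limit
- Compound 2 `C/C=C/C(=O)CC1c2cc(OCc3cc(C)cc(C)c3)c(OCc3cc(C)cc(C)c3)cc2CCN1C(=O)OC(C)(C)C`: > 20000 nM, a limit

Compound 2 gives > 20000 nM, which is a limit of the assay and not a number. It has company there, and the whole picture so far is the limit of > 20000 nM in this assay, at which 2 of the 2 values shown sit. Among the measured compounds shown here, the only measured step is a step that the two limits leave unreadable from compound 1 to compound 2, in which ((prop-1-en-1-yl)carbonyl)methyl replaces ethoxy on a saturated ring carbon, so it offers no size to carry forward.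

The next compound is compound 3 `Cc1cc(C)cc(COc2cc3c(cc2OCc2cc(C)cc(C)c2)CN(C(=O)OC(C)(C)C)CC3)c1`. It has hydrogen in place of ((prop-1-en-1-yl)carbonyl)methyl on that same saturated ring carbon, and the counted change is hydrogen in place of ((prop-1-en-1-yl)carbonyl)methyl on a saturated ring carbon. For the measured compounds named here, with a step that the two limits leave unreadable from compound 1 to compound 2 as the only guide, no step beyond the usual scatter is expected in this assay, and no direction can be argued. The most likely outcome is another limit, although a readable number remains possible. For compound 3 the expected value is 25000 nM, with an estimated range from 10000 nM to 40000 nM. This estimate means an expected step that the limit leaves unreadable from compound 2 to compound 3.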

Compound 3, half-maximal inhibitory concentration: > 20000 nM
Compound 3: a limit, no number; the forecaster's own chance of this, stated with the estimate: 70%; the middle value does not contradict the limit.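

Compound 3 gives > 20000 nM in this assay and that is a limit of the assay, not a number. Among the compounds shown here, compound 1, compound 2 and compound 3 all sit at such a limit, so no step among them can be read. Still open, as far as these compounds go, is whether any change to the shared core gives a readable number in this assay at all.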